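Cyclopropyl in Place of Fluorophenyl: Tolerability on Vero Cells

The compounds below may be only part of what the source reports. "The series", "measured", "known", "first", "only" and "open" are said of these compounds alone.

The series was tested in an ADME assay on Vero cells (Chlorocebus sabaeus) for cytotoxicity, read by MTT assay, with a stated time of 72 h; a lower number here means that less compound is tolerated, a higher number that more compound is tolerated. Within the data shown here, compound 1 `CC1CN(c2cc3c(cc2[N+](=O)[O-])c(=O)c(C(=O)O)cn3-c2ccc(F)cc2)CC(C)O1` is the only member with a number: in this assay compound 1 gives 70800 nM. Compound 2 `CC(C)(C)n1cc(C(=O)O)c(=O)c2cc([N+](=O)[O-])c(N3CCn4cc(C(=O)O)nc4C3)cc21` is recorded in this assay as "not determined" (no result reported), and compound 3 `O=C(O)c1cn2c(n1)CN(c1cc3c(cc1[N+](=O)[O-])c(=O)c(C(=O)O)cn3-c1ccc(F)cc1)CC2` likewise carries in this assay only "not determined" (no result reported); compound 3 therefore stands without a number, and compound 2 is the only other entry in the same position.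

Compound 4 `O=C(O)c1cn2c(n1)CN(c1cc3c(cc1[N+](=O)[O-])c(=O)c(C(=O)O)cn3C1CC1)CC2` is the next member, still to be measured in this assay. It differs from compound 3 in one place: cyclopropyl in place of 4-fluorophenyl on an aromatic nitrogen.

Among the measured compounds shown here, no step between two measured compounds is available, so no computed size can be drawn on. For the measured compounds named here, on the single number available, that of compound 1, and on the shared core that compound 3 and compound 4 carry, the step from compound 3 to compound 4 is expected to be none beyond the scatter, in either direction. In this assay compound 4 is therefore estimated at 80000 nM, with a range from 30000 nM to 200000 nM, and a fair chance that only a limit is reported.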

Compound 4, half-maximal cytotoxic concentration: 142000 nM
Estimate against measurement, compound 4: 1.8-fold (0.25 log units) below, within the range that was stated.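

In this assay, among these compounds, compound 4 gives 142000 nM, while compound 3 carries no number, so no step between compound 3 and compound 4 can be read. The compounds shown leave open what cyclopropyl in place of 4-fluorophenyl changes in this tolerability. No supporting data bear on the result.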